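Swapping the Ethyl on the Amide for a Methoxyazetidine

The source may hold more compounds than are shown below. What is called first, only, known or untested is meant among the compounds shown, and "the series" means these compounds.

Measured so far:
compound 1, `CCC(=O)N1CC[C@H](Oc2ncnc3c2nc(-c2cnc(C)nc2)n3CC)C1`: 3.9 h in an ADME assay (Canis lupus familiaris, strain Beagle) for metabolic stability; a higher number here means that the compound lasts longer, a lower number that the compound disappears faster
compound 2, `CCn1c(-c2cnc(C)nc2)nc2c(N[C@H]3CCN(C(=O)C4CC4)C3)ncnc21`: 4.7 h in this assay

For the measured compounds named here, only two compounds have been measured in this assay. Compound 1 gives 3.9 h, and compound 2 gives 4.7 h; the two numbers lie within the usual scatter of each other, so no difference between them can be claimed. Going by the values given here, no pair of measured compounds differs in just one place, so there is no measured step to lean on.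

Compound 3, `CCn1c(-c2cnc(C)nc2)nc2c(O[C@H]3CCN(C(=O)N4CC(OC)C4)C3)ncnc21`, has not yet been measured. It differs from compound 1 in one place: 3-methoxyazetidin-1-yl in place of ethyl on a carbonyl carbon. The carbonyl that carried a propanoyl group in compound 1 now carries a (3-methoxyazetidin-1-yl)carbonyl group.

Among the compounds with values here, with no measured step to guide the size of the change, the expectation is a modest shift at most, quite possibly none beyond the scatter, and the expected step of a 1.2-fold higher number from compound 1 to compound 3 (0.06 log units; within the scatter) is taken as small. For compound 3 the estimated half-life is 4.5 h, with a range from 2 h to 10 h.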

Compound 3, half-life: 1.2 h
The estimate for compound 3 lay 3.8-fold (0.57 log units) above the measured number, and the stated range ends above it.
By their numbers in this assay, from the lowest: compound 3; then compounds 1 and 2 (each within the scatter of the next).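

For the compounds shown here, the group on this carbonyl carbon can matter: in this assay, putting 3-methoxyazetidin-1-yl in place of ethyl gives a 3.3-fold lower number from compound 1 to compound 3 (0.51 log units; beyond the scatter) and so provides the first step in this small set that clearly stands out from the scatter. The earlier compounds shown here could not show this, as compound 1 and compound 2 differ in more than one place and their values lie within the scatter of each other. The change brings in a four-membered ring, a methoxy group and a nitrogen on the carbonyl carbon all at once, and nothing available here explains the shorter half-life or ties it to any one of these parts.

As far as these compounds go, whether a plain azetidine without the methoxy group, or a longer chain such as butyl in place of ethyl, would give a value closer to compound 1 or to compound 3 remains open. Also open, from the compounds shown here alone, is whether 3-methoxyazetidin-1-yl on the carbonyl of compound 2 would bring a step of similar size.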